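The compounds below may be only part of what the source reports. "The series", "measured", "known", "first", "only" and "open" are said of these compounds alone.

Measured so far in a functional assay on A549 cells (Homo sapiens) for inhibition, read by MTT assay, with a stated time of 72 h, tested at 10 uM; on this read-out higher numbers stand for more inhibition at the one concentration tested (going by the name of the read-out) and lower numbers for less inhibition:
compound 1, `CCOC(=O)C1=C(Nc2ccccc2)S/C(=C\c2ccc(Br)c(O)c2)C1=O`, gives 13.6%.
compound 3, `CCOC(=O)C1=C(Nc2ccccc2)S/C(=C\c2cc(OC)c(O)c(OC)c2)C1=O`, gives 19.2%.
compound 2, `CCOC(=O)C1=C(Nc2ccccc2)S/C(=C\c2ccccc2C(F)(F)F)C1=O`, reaches only a limit of the assay, < 10%.

Of the two numbers measured, compound 1 stands lowest, and compound 3 is its nearest neighbour; the gap between compound 1 and compound 3 lies within the scatter, so the two cannot be told apart. The remaining value is not a number but (the limit of < 10% in this assay, at which 1 of the 3 values shown sits). Among the compounds with values here, no two measured compounds differ in a single place, so no measured step is available to guide an expectation.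

Compound 4, `CCOC(=O)C1=C(Nc2ccccc2)S/C(=C\c2cccnc2)C1=O`, has not yet been measured. It differs from compound 1 in one place: pyridin-3-yl in place of 4-bromo-3-hydroxyphenyl on a double-bonded chain carbon bound to a double-bonded ring carbon. Nothing in the measured set speaks to what this change does, and all three measured compounds sit in the same low region of the read-out. Compound 4 is therefore expected to stay close to compound 1, with a step from compound 1 to compound 4 of a number 2.6 percentage points lower from compound 1 to compound 4 (within the scatter), which is not beyond the scatter. Compound 4 is estimated at 11%, within a range from 3% to 22%, and a report of only the limit would not be surprising.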

Compound 4, a percentage reported as inhibition, at one concentration (the size of the read-out at that concentration, not a potency): < 10%
Compound 4: only a limit was reported; the forecaster's own chance of this, stated with the estimate: 45%; middle value at least 1 percentage points from the limit.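

In this assay, within the data shown here, the exchange of 4-bromo-3-hydroxyphenyl for pyridin-3-yl, on a double-bonded chain carbon bound to a double-bonded ring carbon, gives the only single-place comparison in the set, and it reads as a number at least 3.6 percentage points lower from compound 1 to compound 4 (that floor lies within the scatter) and no gain in inhibition at this position. Compound 4 gives < 10%, which is a limit of the assay and not a number. The true size of the step therefore cannot be read, and the pyridin-3-yl change adds one more compound to the bottom of the read-out, where the range offers no further resolution: the limit of < 10% in this assay, at which 2 of the 4 values shown sit.

The bromine, the hydroxyl and the carbon-only ring all leave in this one change, so the compounds shown do not tell which of them, if any, carries the small signal of compound 1. As far as these compounds go, it also remains open whether an amine or a carboxylic acid on the aromatic ring at this place would lift the read-out clear of the limit.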